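From Amide to Urea: Expecting Compound 4's Growth Inhibition

The source may report more compounds than this note shows. Statements on the series, on what has been measured and on what is new or still open speak of the compounds shown alone.

Measured so far:
Compound 1 `COc1cc(-c2nn(-c3cccc(NC(=O)c4cccc(C(F)(F)F)c4)c3)cc2-c2ccncc2)ccc1Cl` gives > 50000 nM in a functional assay on HOP-62 cells (Homo sapiens) for inhibition, read by sulforhodamine B assay, with a stated time of 48 h; a higher number here means a weaker inhibitor of growth, a lower number a stronger inhibitor of growth.
Compound 2 `O=C(Nc1cccc(-n2cc(-c3ccncc3)c(-c3ccc(Cl)c(O)c3)n2)c1)Nc1cc(C(F)(F)F)cc(C(F)(F)F)c1` gives 1980 nM in this assay.
Compound 3 `O=C(Nc1cccc(-n2cc(-c3ccncc3)c(-c3ccc(Cl)c(O)c3)n2)c1)Nc1ccc(Cl)c(C(F)(F)F)c1` gives 7830 nM in this assay.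

For compound 1 the assay reports only a limit, (the limit of > 50000 nM in this assay, at which 1 of the 3 values shown sits), so no actual number stands for it. Compound 2 and compound 3, both of which carry a urea rather than the amide of compound 1, do give numbers.

Compound 4 `COc1cc(-c2nn(-c3cccc(NC(=O)Nc4ccc(Cl)c(Cl)c4)c3)cc2-c2ccncc2)ccc1Cl` has not yet been measured. It differs from compound 1 in one place: (3,4-dichlorophenyl)amino in place of 3-(trifluoromethyl)phenyl on a carbonyl carbon. Going by the values given here, no measured pair shows this exact change, so the size of the step can only be guessed. Compound 1 sits at a limit of the assay. I expect the step of an at least 4.1-fold lower number from compound 1 to compound 4 (0.61 log units; beyond the scatter) to run toward a stronger inhibitor because compound 2 gives 1980 nM and compound 3 gives 7830 nM with a urea in place. For compound 4 I therefore estimate 12000 nM, with a range from 3000 nM to 50000 nM.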

Compound 4, concentration for total growth inhibition: 4900 nM
Compound 4: the middle estimate sits 2.4-fold (0.39 log units) above what was measured; measured number inside the range.
By their numbers in this assay, from the lowest: compound 2; then compounds 4 and 3 (each within the scatter of the next). At a limit, above all of these: compound 1.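

In this assay, putting (3,4-dichlorophenyl)amino in place of 3-(trifluoromethyl)phenyl on a carbonyl carbon gives an at least 10-fold lower number from compound 1 to compound 4 (1.00 log units; beyond the scatter). This shows that the amide-to-urea swap, together with the new ring substituents, can yield a real number on the core that keeps the methoxy group, which compounds 2 and 3 do not carry. The true size of the step cannot be read because compound 1 stands at a limit of the assay, not at a number: the limit of > 50000 nM in this assay, at which 1 of the 4 values shown sits.

This single change alters both the link to the ring and the groups on that ring, so the compounds shown cannot separate the two contributions. From the compounds shown here alone, it also remains open how a urea would behave on this core with an unsubstituted phenyl ring or with a nitrile on the ring.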